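Cytotoxicity notes on a benzofuran bis-amidine series

This account rests on a few compounds, and the source may have more. Where it says the series, first, only, none or still open, it means among the compounds named here.

Measured compounds:
- compound 1, `N=C(N)c1cccc(-c2cc3cc(C(=N)N)ccc3o2)c1`: 21200 nM
- compound 2, `c1cc(C2=NCCN2)cc(-c2cc3ccc(C4=NCCN4)cc3o2)c1`: 12800 nM
- compound 3, `COc1ccc(C(=N)N)cc1-c1cc2cc(C(=N)N)ccc2o1`: 179000 nM

All three were run in an ADME assay on L6 cells (Rattus norvegicus) for cytotoxicity; on this read-out higher numbers stand for weaker inhibition and lower numbers for stronger inhibition. Compound 1 gives 21200 nM in this assay, compound 2 gives 12800 nM and compound 3 gives 179000 nM. The values of compound 1 and compound 2 lie within the scatter of each other, so no order is drawn between them; compound 3 sits well apart from both.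

One single-point change is measured: methoxy in place of hydrogen on an aromatic carbon. It produced an 8.4-fold higher number from compound 1 to compound 3 (0.93 log units; beyond the scatter), a weakening of cytotoxicity that is beyond the scatter but of modest size.

The difference between the core of compound 1 and the core of compound 2 is not broken down here.

Compound 4, `COc1ccc(C2=NCCN2)cc1-c1cc2ccc(C3=NCCN3)cc2o1`, has not yet been measured. It relates to compound 2 as compound 3 relates to compound 1: methoxy in place of hydrogen on an aromatic carbon. The two changes are the same kind of change rather than the same: in compound 3 the entering methoxy sits para to a group of 3 heavy atoms, in compound 4 it sits para to a group of 5 heavy atoms.

Among the compounds with values here, with only the one measured instance of this change, the expectation for compound 4 rests on carrying over the step from compound 1 to compound 3, which was an 8.4-fold higher number from compound 1 to compound 3 (0.93 log units; beyond the scatter), onto the value of compound 2, 12800 nM. Compound 4 is therefore expected to show a step of a 7.4-fold higher number from compound 2 to compound 4 (0.87 log units; beyond the scatter) relative to compound 2, a weakening of similar size. The estimate for compound 4 in this assay is 95000 nM, with a plausible range from 35000 nM to 260000 nM.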

Compound 4, half-maximal inhibitory concentration: 11100 nM
Beside the measured number, compound 4's estimate is 8.6-fold (0.93 log units) above it; the whole stated range lies above it.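

In this assay, methoxy in place of hydrogen on an aromatic carbon gave a 1.2-fold lower number from compound 2 to compound 4 (0.06 log units; within the scatter), so the clear weakening of cytotoxicity seen on the core of compound 1 does not appear on this second core. The outcome of this change therefore depends on the core it is made on, and the two measured instances do not agree: the same change on two cores in this assay, an 8.4-fold higher number (0.93 log units; beyond the scatter) from compound 1 to compound 3 and a 1.2-fold lower number (0.06 log units; within the scatter) from compound 2 to compound 4, 9.7-fold (0.99 log units) apart, beyond the scatter of two such steps This does not show which difference between the two cores decides the outcome, since those cores differ in more than one place and the comparison rests on just two pairs, so it gives no general rule for the series beyond compound 1, compound 2, compound 3 and compound 4.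

Within the data shown here, still open is whether a hydroxyl, a chlorine atom or a longer ethoxy chain in the methoxy position would give a step like the one to compound 3 or one within the scatter like the one to compound 4, on either core. Also open, on these data alone, is how a carboxylic acid or a primary amine in place of the groups that differ between the two cores would read in this assay.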